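The compounds below may be only part of what the source reports. "The series", "measured", "known", "first", "only" and "open" are said of these compounds alone.

Of the compounds shown here, three have so far been measured in a functional assay on CHO cells for antagonist activity at prostaglandin E2 receptor EP3 subtype (Homo sapiens), read by cAMP accumulation, with a stated time of 30 min; a lower number here means a stronger inhibitor, a higher number a weaker inhibitor. Compound 1, `C/C(=C1/OC(=O)NC1=O)C(c1ccc(-c2ccc3cccc(F)c3c2)[nH]c1=O)C(C)C`, gives 39 nM in this assay, and compound 2, `CCC(/C=C1\OC(=O)NC1=O)(CC)c1ccc(-c2ccc3cc(F)cc(F)c3c2)[nH]c1=O`, gives 45 nM in this assay; these two values lie within the usual scatter of each other. Compound 3, `CC(C)C(c1ccc(-c2ccc3cccc(F)c3c2)[nH]c1=O)C1SC(=O)NC1=O`, gives 110 nM in this assay, the highest number of the three. Among the measured compounds shown here, the one measured step that reaches compound 3 is a 2.8-fold higher number from compound 1 to compound 3 (0.45 log units; beyond the scatter), a modest weakening of inhibition that nonetheless falls beyond the scatter.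

Compound 4, `CC(C)C(CC1NC(=O)NC1=O)c1ccc(-c2ccc3cccc(F)c3c2)[nH]c1=O`, has not yet been measured. It differs from compound 3 in one place: (2,5-dioxoimidazolidin-4-yl)methyl in place of 2,4-dioxo-1,3-thiazolidin-5-yl on a saturated chain carbon bound to an aromatic carbon and a saturated chain carbon. For the measured compounds named here, the only measured step that bears on this position is a 2.8-fold higher number from compound 1 to compound 3 (0.45 log units; beyond the scatter), which shows that exchanging the five-membered ring at this carbon moves the number by a modest amount; no measured pair contains the (2,5-dioxoimidazolidin-4-yl)methyl group itself. Because a 2.8-fold higher number from compound 1 to compound 3 (0.45 log units; beyond the scatter) was modest, one expects the next exchange at the same position to be modest as well, and the expected step is a 1.4-fold higher number from compound 3 to compound 4 (0.13 log units; within the scatter). Compound 4 is therefore estimated at 150 nM in this assay, with a range from 50 nM to 500 nM.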

Compound 4, half-maximal inhibitory concentration: 31 nM
The estimate for compound 4 lay 4.8-fold (0.68 log units) above the measured number, and the stated range ends above it.
By their numbers in this assay, from the lowest: compounds 4, 1 and 2 (each within the scatter of the next); then compound 3.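

In this assay, the exchange at this saturated chain carbon gives a 3.5-fold lower number from compound 3 to compound 4 (0.55 log units; beyond the scatter), so the earlier rise on moving to the 2,4-dioxo-1,3-thiazolidin-5-yl group can be reversed by another five-membered ring group at the same carbon. The second new step, a 1.3-fold lower number from compound 1 to compound 4 (0.10 log units; within the scatter), places the (2,5-dioxoimidazolidin-4-yl)methyl group level with the group carried by compound 1, so among these three compounds, compound 3 alone stands apart, with a higher number than each of the other two by steps beyond the scatter. No measurement offered here accounts for the difference between the thiazolidine and imidazolidine groups at this carbon.

The step from compound 3 to compound 4 alters the ring and adds a methyl link in one exchange, and the compounds shown do not separate these two changes, which a (2,4-dioxo-1,3-thiazolidin-5-yl)methyl group would address. On these data alone, it also remains open whether this carbon would hold similar numbers with a carboxylic acid in place of the five-membered ring, or with a longer chain leading to the (2,5-dioxoimidazolidin-4-yl) ring.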